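From Butyl to tert-Butyl on the Amide Nitrogen

The source may report more compounds than this note shows. Statements on the series, on what has been measured and on what is new or still open speak of the compounds shown alone.

Of the compounds shown here, three built on one shared core have been measured in a functional assay on the whole organism (strain Wistar) for inhibition, with Rattus norvegicus as the target, read by paw edema, with stated times of 60 min and 2 h, at a dose of 100 mg/kg by the oral route; a lower number here means less inhibition, a higher number more inhibition at the dose given (going by the name of the read-out). Compound 1 `COc1cc2c(cc1OC)C(CC(=O)O)CC2` gives 24%. Compound 2 `CNC(=O)CC1CCc2cc(OC)c(OC)cc21` gives 30%, and compound 3 `CCCCNC(=O)CC1CCc2cc(OC)c(OC)cc21` gives 24%. Compound 3 thus stands level with compound 1 at the digits given, the two together being the lowest of the three numbers; its nearest neighbour is compound 1, with no change at the digits printed from compound 1 to compound 3 (within the scatter), and its furthest is compound 2, with a number 6 percentage points lower from compound 2 to compound 3 (within the scatter).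

The unmeasured compound 4 `COc1cc2c(cc1OC)C(CC(=O)NC(C)(C)C)CC2` differs from compound 3 in one place: tert-butyl in place of butyl on an amide-type nitrogen. Among the compounds with values here, the steps that bear on this change are those at the carbonyl and its attached nitrogen: a number 6 percentage points higher from compound 1 to compound 2 (within the scatter), no change at the digits printed from compound 1 to compound 3 (within the scatter) and a number 6 percentage points lower from compound 2 to compound 3 (within the scatter). All three lie within the scatter, so replacing the hydroxy by methylamino or butylamino, or extending the chain on the amide-type nitrogen by propyl, has moved nothing beyond the scatter in this assay. Exchanging butyl for tert-butyl on that same nitrogen is therefore expected to give a step of no change beyond the scatter in this assay. Compound 4 is accordingly estimated at 25%, with a range from 14% to 36%. That amounts to an expected step of a number 1 percentage points higher from compound 3 to compound 4 (within the scatter).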

Compound 4, a percentage reported as inhibition, in the whole organism at one dose (the size of the read-out at that dose, not a potency): 32%
For compound 4 the middle estimate is 7 percentage points below the measured one; measured number inside the range.
By their numbers in this assay, from the lowest: compounds 1, 3, 2 and 4 (each within the scatter of the next).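

In this assay, exchanging butyl for tert-butyl on the amide-type nitrogen gives a step that stays inside the scatter: a number 8 percentage points higher from compound 3 to compound 4 (within the scatter). The new compound also stays within the scatter of the other two, with a number 2 percentage points higher from compound 2 to compound 4 (within the scatter) and a number 8 percentage points higher from compound 1 to compound 4 (within the scatter), so methyl, butyl and tert-butyl on this nitrogen, and hydroxy on the carbonyl carbon, have so far produced no step beyond the scatter. The earlier compounds varied only the length of the chain, whereas this pair shows that rearranging the same four carbon atoms also yields no difference that this assay can separate from the scatter, and nothing measured here offers an explanation for the small differences between the numbers.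

From the compounds shown here alone, it remains open whether any group on this nitrogen can produce a step beyond the scatter, for instance a benzyl or cyclohexyl group, or a second methyl in place of the amide hydrogen. The four compounds also leave open what the two methoxy groups of the shared core contribute, since all four carry them, and replacing them with hydroxy groups would address that question.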